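Methylsulfanyl on a fused core, with and without a sugar

The compounds below may be only part of what the source reports. "The series", "measured", "known", "first", "only" and "open" are said of these compounds alone.

Compound 1 `Cc1nsc2[nH]cnc12`: 17000 nM
Compound 2 `CSc1nc2c(C)nsc2[nH]1`: 13000 nM
Compound 3 `Cc1nsc2c1ncn2[C@H]1C[C@H](O)[C@@H](CO)O1`: > 100000 nM

All three were tested in a functional assay on L1210 cells (Mus musculus) for antiproliferative activity; a lower number here means a stronger inhibitor, a higher number a weaker inhibitor. From compound 1 to compound 2 the change is methylsulfanyl in place of hydrogen on an aromatic carbon, and the step is a 1.3-fold lower number from compound 1 to compound 2 (0.12 log units; within the scatter). Compound 3 carries a larger core, and the difference between its core and that of compound 1 is not broken down here. Compound 3 reaches only a limit, (the limit of > 100000 nM in this assay, at which 1 of the 3 values shown sits). Compound 4 `CSc1nc2c(C)nsc2n1[C@H]1C[C@H](O)[C@@H](CO)O1` differs from compound 3 by methylsulfanyl in place of hydrogen on an aromatic carbon; this is the same kind of change as before, here next to the ring atom that bears a group of 8 heavy atoms. Since the earlier step stayed within the scatter, the expected step is a number no higher from compound 3 to compound 4 (the limit leaves the size open). Compound 4 is estimated at 100000 nM, between 30000 nM and 300000 nM.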

Compound 4, half-maximal inhibitory concentration: > 100000 nM
Compound 4: only a limit was reported (the forecaster's own chance of this, stated with the estimate: 70%); the middle value lies on the limit itself.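

Compound 3 and compound 4 each reach only a limit in this assay, so the step between them cannot be read: the limit of > 100000 nM in this assay, at which 2 of the 4 values shown sit.

The compounds shown leave open whether methylsulfanyl in place of hydrogen on an aromatic carbon changes the number at all when the ring atom bears a group of 8 heavy atoms.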